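This account rests on a few compounds, and the source may have more. Where it says the series, first, only, none or still open, it means among the compounds named here.

Of the compounds shown here, two sharing one core have so far been tested in an assay on BAF cells for inhibition of ribosomal protein S6 kinase alpha-2 (Mus musculus); on this read-out lower numbers stand for stronger inhibition and higher numbers for weaker inhibition. Compound 1, `COc1cccc(F)c1-c1cccc2nc(Nc3ccccc3)oc12`, reaches only a limit of the assay: in this assay compound 1 gives > 20000 nM. Compound 2, `COc1cc(Nc2nc3cccc(-c4ccccc4OC(F)(F)F)c3o2)cc(OC)c1OC`, likewise stops at a limit, giving > 20000 nM in this assay. Compound 2 thus stands at a limit rather than at a number. Every value obtained so far sits at that same point, (the limit of > 20000 nM in this assay, at which 2 of the 2 values shown sit). Compound 3, `COc1ccc(F)cc1-c1cccc2nc(Nc3cc(OC)c(OC)c(OC)c3)oc12`, has not been measured. It differs from compound 2 in one place: 5-fluoro-2-methoxyphenyl in place of 2-(trifluoromethoxy)phenyl on an aromatic carbon. Since both measured values are limits, no measured step size can be given. With only limits in hand, the step that the limit leaves unreadable from compound 2 to compound 3 is expected to stay within the usual scatter. Compound 3 is therefore estimated to give about 30000 nM, within a range from 8000 nM to 100000 nM, most probably again as a limit of this assay.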

Compound 3, half-maximal inhibitory concentration: 3700 nM
For compound 3 the middle estimate is 8.1-fold (0.91 log units) above the measured one, outside the stated range (below it).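

In this assay, placing 5-fluoro-2-methoxyphenyl instead of 2-(trifluoromethoxy)phenyl on this aromatic carbon gives an at least 5.4-fold lower number from compound 2 to compound 3 (0.73 log units; beyond the scatter). The group at this one place can therefore lift a compound off the limit of the assay, so the position is not indifferent to what it carries. Compound 3 is also the only compound shown with a value that is an actual number, which gives later changes a reference point that can be read in both directions.

The swap changes the whole aryl group at once, so the compounds shown do not separate the part played by the fluorine from that of the methoxy group, nor say whether an amine or a carboxylic acid on this ring would give a lower or a higher number. Little can yet be compared, as most of the values give no number at all: the limit of > 20000 nM in this assay, at which 2 of the 3 values shown sit.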